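Amino group exchange from compound 3 to compound 4

A few compounds are considered here, and "the series" means these few. Any claim that something is new, unique, unknown or untested is made for them only; others in the source may bear on it.

Values in an ADME assay on A549 cells (Homo sapiens) for cytotoxicity, read by resazurin assay, with a stated time of 48 h; a lower number here means that less compound is tolerated, a higher number that more compound is tolerated:
compound 1 `CC(C)CNc1ccc(NC(=O)c2cc(Cl)ccc2O)c(Cl)c1`: 60000 nM
compound 2 `O=C(Nc1ccc(NCC2CCCC2)cc1Cl)c1cc(Cl)ccc1O`: 21500 nM
compound 3 `CCN(CC)c1ccc(NC(=O)c2cc(Cl)ccc2O)c(Cl)c1`: 55500 nM

Compound 3 stands in the upper pair of this set of three. Its nearest neighbour is given by a 1.1-fold lower number from compound 1 to compound 3 (0.03 log units; within the scatter). The clearly lower value lies in the other direction, as shown by a 2.6-fold higher number from compound 2 to compound 3 (0.41 log units; beyond the scatter).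

Compound 4 `O=C(Nc1ccc(N(CC2CC2)CC2CC2)cc1Cl)c1cc(Cl)ccc1O` carries bis(cyclopropylmethyl)amino in place of diethylamino on an aromatic carbon.

Two measured exchanges bear on this change. Going by the values given here, compound 2 is the only measured compound with a ring in this amino group, and it gives the lower number, seen in a 2.8-fold lower number from compound 1 to compound 2 (0.45 log units; beyond the scatter), a modest step. Compound 3 shows that exchanging one ring-free amino group for another gave nothing beyond the scatter, in a 1.1-fold lower number from compound 1 to compound 3 (0.03 log units; within the scatter). Among the compounds with values here, no measured compound has two rings in this group, so the basis is thin. A modest downward step is therefore expected in this assay, close in size to the gap between compound 2 and compound 3. The expected step is a 2.1-fold lower number from compound 3 to compound 4 (0.31 log units; beyond the scatter). For compound 4 the estimated value is 27000 nM, with an expected range of 12000 nM to 55000 nM.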

Compound 4, half-maximal cytotoxic concentration: 12800 nM
Estimate against measurement, compound 4: 2.1-fold (0.32 log units) above; measured number inside the range.
By their numbers in this assay, from the lowest: compounds 4 and 2 (each within the scatter of the next); then compounds 3 and 1 (each within the scatter of the next).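

In this assay, going by these compounds alone, the ring-bearing bis(cyclopropylmethyl)amino group gives a clear drop from diethylamino (a 4.3-fold lower number from compound 3 to compound 4 (0.64 log units; beyond the scatter)) and from isobutylamino (a 4.7-fold lower number from compound 1 to compound 4 (0.67 log units; beyond the scatter)), so the lower numbers at this position are no longer confined to the single example with a cyclopentyl ring. Compound 4 has no hydrogen-bond donor in this group, yet its separation from the (cyclopentylmethyl)amino group stays within the scatter (a 1.7-fold lower number from compound 2 to compound 4 (0.23 log units; within the scatter)), so the low end of the set does not depend on a donor in this group or on the cyclopentyl ring, and two three-membered rings give no step beyond the scatter from one five-membered ring. Across these four compounds, the two with a ring in the amino group sit at the low end and the two ring-free ones at the high end, with no compound against this split.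

Ring and group size rise together here, so the compounds do not separate them; a morpholine or a straight dibutylamino group at this aromatic carbon would begin to do so. Nothing measured here explains the drop in this number.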